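The compounds below may be only part of what the source reports. "The series", "measured", "known", "first", "only" and "open" are said of these compounds alone.

Measured compounds:
compound 1 `COc1ccc(Oc2ccc3c(NCCCNCc4cc(F)ccc4OC)ccnc3c2)cc1`, 317 10^-6 cm/s
compound 2 `CC(C)Cc1ccc2c(NCCCNCc3ccco3)ccnc2c1`, 23 10^-6 cm/s
compound 3 `COc1cccc(CNCCCNc2ccnc3cc(Oc4ccc(Cl)cc4)ccc23)c1O`, 317 10^-6 cm/s

In an ADME assay for permeability, using PAMPA, with a stated time of 30 min, at pH 7.4 (on this read-out lower numbers stand for lower permeability and higher numbers for higher permeability), compound 2 gives the lowest of the three numbers; compound 1 and compound 3 both give a number that stands well beyond the usual scatter above it. Among the measured compounds shown here, no pair of these measured compounds differs in only one place, so no single measured step is known. Compound 4 `Fc1ccc(-c2ccc3c(NCCCNCc4ccco4)ccnc3c2)cc1` has not yet been measured. It differs from compound 2 as follows: 4-fluorophenyl in place of isobutyl on an aromatic carbon. Since both of the higher measured compounds carry an aromatic ring at a comparable position, a rise beyond the scatter is expected from compound 2 to compound 4, namely a 6.5-fold higher number from compound 2 to compound 4 (0.81 log units; beyond the scatter). Compound 4 is therefore estimated at 150 10^-6 cm/s, with a range from 40 10^-6 cm/s to 400 10^-6 cm/s.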

Compound 4, apparent permeability: 237 10^-6 cm/s
Compound 4: the middle estimate sits 1.6-fold (0.20 log units) below what was measured; low and high end bracket the measured number.
By their numbers in this assay, from the lowest: compound 2; then compounds 4, 1 and 3 (each within the scatter of the next).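

Among the compounds shown here, this is the first single change that can be read on its own in this assay: with the rest of the molecule unchanged, 4-fluorophenyl in place of isobutyl on this aromatic carbon gives a 10-fold higher number from compound 2 to compound 4 (1.01 log units; beyond the scatter). The group at this position can therefore move the read-out well beyond the usual scatter. Nothing available explains the rise.

It remains open whether the fluorine plays any part, since a plain phenyl is not among these compounds. On these data alone, how a straight alkyl chain or an amine at this carbon would read also remains unknown.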